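Amide substituent variation on a sulfonamide glutamine series

A few compounds are considered here, and "the series" means these few. Any claim that something is new, unique, unknown or untested is made for them only; others in the source may bear on it.

Measured so far in an assay for inhibition of matrix metalloproteinase-9 (Homo sapiens), with stated times of 1 h, 1 min and 30 min; on this read-out lower numbers stand for stronger inhibition and higher numbers for weaker inhibition:
- compound 1, `NC(=O)CC[C@H](NS(=O)(=O)c1ccc([N+](=O)[O-])cc1)C(=O)O`: 7000 nM
- compound 2, `CNC(=O)CC[C@H](NS(=O)(=O)c1ccc([N+](=O)[O-])cc1)C(=O)O`: 7500 nM
- compound 3, `CC(C)CNC(=O)CC[C@H](NS(=O)(=O)c1ccc([N+](=O)[O-])cc1)C(=O)O`: 5140 nM

Compound 3 carries the lowest number of the three, but both neighbours sit within the usual scatter of it: compound 1 is nearer, compound 2 a little further off. Neither a 1.4-fold lower number from compound 1 to compound 3 (0.13 log units; within the scatter) nor a 1.5-fold lower number from compound 2 to compound 3 (0.16 log units; within the scatter) moves beyond the scatter, and a 1.1-fold higher number from compound 1 to compound 2 (0.03 log units; within the scatter) is flat as well. Growth of the amide substituent from hydrogen through methyl to isobutyl has therefore produced no step that can be distinguished from noise.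

Compound 4, `O=C(CC[C@H](NS(=O)(=O)c1ccc([N+](=O)[O-])cc1)C(=O)O)NCc1ccccc1`, continues along the same vector: phenyl in place of isopropyl on a saturated chain carbon bound to an amide-type nitrogen. Within the data shown here, the only steps bearing on this change are those just named, and all were within the scatter. A phenyl in place of isopropyl is a larger change than any of those, but the series gives no evidence that this position is sensitive, so the expected step in this assay is small, with at most a slight shift toward a lower number. The expected step is a 1.3-fold lower number from compound 3 to compound 4 (0.11 log units; within the scatter). Compound 4 is thus estimated at 4000 nM, with a range of 1500 nM to 11000 nM.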

Compound 4, half-maximal inhibitory concentration: 6370 nM
For compound 4 the middle estimate is 1.6-fold (0.20 log units) below the measured one; measured number inside the range.
By their numbers in this assay, from the lowest: compounds 3, 4, 1 and 2 (each within the scatter of the next).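

In this assay, among these compounds, the only ring, phenyl in place of isopropyl on a saturated chain carbon bound to an amide-type nitrogen, gives no step that can be told from noise (a 1.2-fold higher number from compound 3 to compound 4 (0.09 log units; within the scatter)), so a six-membered aromatic ring of carbon only, in place of the isopropyl, leaves the read-out flat. The same holds against the smaller amides (a 1.2-fold lower number from compound 2 to compound 4 (0.07 log units; within the scatter)) and against the unsubstituted amide (a 1.1-fold lower number from compound 1 to compound 4 (0.04 log units; within the scatter)), so hydrogen, methyl, isobutyl and benzyl on the amide-type nitrogen all lie within the scatter of one another, and the flat picture now extends to an aromatic substituent as well as to alkyl ones. No measurement available here explains why this position shows so little response.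

From the compounds shown here alone, whether a carboxylic acid or an amine on the benzyl ring, or a longer chain in place of benzyl, would give a step beyond the scatter remains open. Also open, going by these compounds, is whether the same flat response would hold on a core other than that of compound 1.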